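The source may report more compounds than this note shows. Statements on the series, on what has been measured and on what is new or still open speak of the compounds shown alone.

Compound 1 `CSc1c(F)cccc1NCC1=NCCN1` and compound 3 `CSc1ccc(C(F)(F)F)cc1NCC1=NCCN1` both carry a methylsulfanyl group on the core, but the difference between the two cores is not broken down here. In an assay for binding affinity to Alpha-1B adrenergic receptor (Homo sapiens), read by radioligand binding (on this read-out lower numbers stand for stronger inhibition and higher numbers for weaker inhibition), compound 1 gives 240 nM, while compound 3 gives 2040 nM. Compound 2 `CS(=O)(=O)c1c(F)cccc1NCC1=NCCN1` is obtained from compound 1 by methylsulfonyl in place of methylsulfanyl on an aromatic carbon; in this assay compound 2 gives 2290 nM, so that a 9.5-fold higher number from compound 1 to compound 2 (0.98 log units; beyond the scatter). Of the three measured numbers, compound 3 lies nearest compound 2, within the scatter, and farthest from compound 1, beyond it. Compound 4 `CS(=O)(=O)c1ccc(C(F)(F)F)cc1NCC1=NCCN1` relates to compound 3 by methylsulfonyl in place of methylsulfanyl on an aromatic carbon, the same kind of change, although here the site is ortho to a group of 7 heavy atoms and para to a trifluoromethyl group rather than ortho to a fluoro group. Going by the values given here, the only measured instance of this kind of change is the step from compound 1 to compound 2, a 9.5-fold higher number from compound 1 to compound 2 (0.98 log units; beyond the scatter), and the expectation for compound 4 rests on that single step. A step of roughly a 5.9-fold higher number from compound 3 to compound 4 (0.77 log units; beyond the scatter) in this assay is therefore expected for compound 4. Compound 4 is thus estimated at 12000 nM, with a likely range from 4000 nM to 40000 nM.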

Compound 4, inhibition constant: < 10000 nM
Compound 4 ended at the assay's limit; the forecaster's own chance of this, stated with the estimate: 25%; middle value at least 1.2-fold (0.07 log units) from the limit.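

In this assay compound 4 gives < 10000 nM, which is a limit of the assay and not a number, so the step from compound 3 to compound 4 cannot be read. The compounds shown leave open whether methylsulfonyl in place of methylsulfanyl shifts the number on the core of compound 3 as it does on the core of compound 1.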